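Removing the aryl fluorine from compound 1

The source may hold more compounds than are shown below. What is called first, only, known or untested is meant among the compounds shown, and "the series" means these compounds.

Compound 1 `CNC(=O)c1cc(Oc2ccc(NC(=O)c3cc(-c4ccc(F)cc4)ncn3)cc2F)ccn1` sits at the limit in a functional assay on PC-3 cells (Homo sapiens) for cytotoxicity, read by MTT assay, with a stated time of 72 h; a lower number here means a stronger inhibitor, a higher number a weaker inhibitor: in this assay compound 1 gives > 100000 nM, a limit rather than a number. The same holds for compound 2 `CNC(=O)c1cc(Oc2ccc(NC(=O)c3cc(-c4ccc(F)cc4)ncn3)cc2)ccn1`, which in this assay gives > 100000 nM, again only a limit. Among the three measured compounds only compound 3 `CNC(=O)c1cc(Oc2ccc(NC(=O)c3nccc(-c4ccc(C)cc4)n3)cc2F)ccn1` gives a number, 28400 nM in this assay. Among the measured compounds shown here, the single measured step, a step that the two limits leave unreadable from compound 1 to compound 2, sits the limit of > 100000 nM in this assay, at which 2 of the 3 values shown sit, and so tells nothing about the size of a change.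

Compound 4 `CNC(=O)c1cc(Oc2ccc(NC(=O)c3cc(-c4ccccc4)ncn3)cc2F)ccn1` differs from compound 1 by hydrogen in place of fluoro on an aromatic carbon. For the measured compounds named here, no measured step concerns this position; the only single-point change available, from compound 1 to compound 2, is unreadable between two limits. The expectation for compound 4 is therefore built on compound 1 alone: a limit start, no readable step, and a change that removes one fluorine. Compound 4 is expected to remain near the limit, with a step of a number no higher from compound 1 to compound 4 (the limit leaves the size open) taken as no change beyond the scatter. The estimate for compound 4 is 100000 nM, within 30000 nM to 300000 nM.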

Compound 4, half-maximal inhibitory concentration: 44300 nM
Estimate against measurement, compound 4: 2.3-fold (0.35 log units) above; the range from low to high includes it.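

In this assay, among the compounds shown here, going from 4-fluorophenyl to phenyl gives the first readable step, an at least 2.2-fold lower number from compound 1 to compound 4 (0.35 log units; beyond the scatter). The start of that step, compound 1, is only a limit, so the size printed is a floor and not a measured gap: the limit of > 100000 nM in this assay, at which 2 of the 4 values shown sit. The fluoro group on this ring, on an aromatic carbon para to a large group, is therefore a place where one atom change brings a compound from the limit to a number, whereas the same swap leading to compound 2 cannot be read.

On these data alone, how far the true value of compound 1 lies from that of compound 4 stays open. Also open, as far as these compounds go, is whether an amine, a methoxy group or a carboxylic acid at this place on the phenyl ring would carry the number further in either direction.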